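Trifluoromethyl in place of nitro: an expected flat step

This account rests on a few compounds, and the source may have more. Where it says the series, first, only, none or still open, it means among the compounds named here.

Three compounds share one core and differ only in the group on an aromatic carbon. Compound 1 `Clc1ccc(OC(CCn2ccnc2)c2ccccc2)cc1` gives 84900 nM in a functional assay on U-937 cells (Homo sapiens) for cytotoxicity; on this read-out higher numbers stand for lower toxicity in this test and lower numbers for higher toxicity in this test. Compound 2 `Cc1ccc(OC(CCn2ccnc2)c2ccccc2)cc1` gives 141000 nM in this assay, and compound 3 `O=[N+]([O-])c1ccc(OC(CCn2ccnc2)c2ccccc2)cc1` gives 97200 nM. Compound 3 stands second highest of the three numbers; compound 1 is its nearest neighbour and compound 2 its furthest, and both gaps are within the scatter. Compound 4 `FC(F)(F)c1ccc(OC(CCn2ccnc2)c2ccccc2)cc1` arises from compound 3 by trifluoromethyl in place of nitro on an aromatic carbon. All three measured steps bear on this exchange of one group for another at the same place: a 1.7-fold higher number from compound 1 to compound 2 (0.22 log units; within the scatter), a 1.1-fold higher number from compound 1 to compound 3 (0.06 log units; within the scatter) and a 1.5-fold lower number from compound 2 to compound 3 (0.16 log units; within the scatter). Because a 1.5-fold lower number from compound 2 to compound 3 (0.16 log units; within the scatter) and its two companions lie within the scatter, no step beyond the scatter is expected in this assay for compound 4, in neither direction. The step from compound 3 to compound 4 is estimated as a 1.0-fold lower number from compound 3 to compound 4 (0.01 log units; within the scatter). Compound 4 is therefore expected to give 95000 nM, within a range of 45000 nM to 200000 nM.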

Compound 4, half-maximal cytotoxic concentration: 86000 nM
Beside the measured number, compound 4's estimate is 1.1-fold (0.04 log units) above it; measured number inside the range.
By their numbers in this assay, from the lowest: compounds 1, 4, 3 and 2 (each within the scatter of the next).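

At this place, on an aromatic carbon para to a large group, a fourth group again leaves this assay undivided: the piece now holds a 1.1-fold lower number from compound 3 to compound 4 (0.05 log units; within the scatter) and a 1.6-fold lower number from compound 2 to compound 4 (0.21 log units; within the scatter) and a 1.0-fold higher number from compound 1 to compound 4 (0.01 log units; within the scatter) as its new steps. The exchange also removes the hydrogen-bond acceptors counted for nitro, as trifluoromethyl has none, so the flat picture now extends to a group with no such acceptors. No measurement is at hand that would explain this flatness.

From the compounds shown here alone, whether a carboxylic acid, an amine or a longer chain at this place would produce a step beyond the scatter remains open. The compounds shown also leave open whether a change elsewhere on the shared core would prove as flat in this assay as these exchanges.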